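This account rests on a few compounds, and the source may have more. Where it says the series, first, only, none or still open, it means among the compounds named here.

Compound 3, `COC(=O)c1cc(-c2cccc(NC(=O)c3ccc(/C=C/C(=O)c4ccc(OC)cc4)cc3)c2)on1`, carries a 4-methoxyphenyl group on its carbonyl carbon. In an ADME assay on Vero cells (Chlorocebus sabaeus) for cytotoxicity, read by MTT assay, with a stated time of 72 h (on this read-out lower numbers stand for higher toxicity in this test and higher numbers for lower toxicity in this test), compound 3 gives only a limit, > 10 ug/mL, and not a number. Compound 1, `COC(=O)c1cc(-c2cccc(NC(=O)c3ccc(/C=C/C(=O)c4cc(F)ccc4F)cc3)c2)on1`, also stands at a limit in this assay, > 40 ug/mL. Compound 2, `COC(=O)c1cc(-c2cccc(NC(=O)c3ccc(/C=C/C(=O)c4cccc(C(F)(F)F)c4)cc3)c2)on1`, likewise reaches only a limit, > 20 ug/mL. The steps between these three compounds, a step that the two limits leave unreadable from compound 1 to compound 3, a step that the two limits leave unreadable from compound 2 to compound 3 and a step that the two limits leave unreadable from compound 1 to compound 2, cannot be read from such values, as the limit of > 10 ug/mL in this assay, at which 1 of the 3 values shown sits, the limit of > 20 ug/mL in this assay, at which 1 of the 3 values shown sits, and the limit of > 40 ug/mL in this assay, at which 1 of the 3 values shown sits, show.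

Compound 4, `COC(=O)c1cc(-c2cccc(NC(=O)c3ccc(/C=C/C(=O)c4ccc(OC)cc4OC)cc3)c2)on1`, differs from compound 3 by methoxy in place of hydrogen on an aromatic carbon, so that the group on the carbonyl carbon becomes 2,4-dimethoxyphenyl. Among the measured compounds shown here, none of the measured steps bears on this exact change, and none of them has a readable size; the three limits only place every compound at or past the stated concentrations. Compound 4 is therefore expected to behave like compound 3 and the others, with a step that the limit leaves unreadable from compound 3 to compound 4 in this assay, that is, nothing beyond the scatter. Compound 4 is estimated to fall near 30 ug/mL, within a range from 10 ug/mL to 80 ug/mL, and it is quite likely that this assay again returns only a limit.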

Compound 4, half-maximal cytotoxic concentration: > 50 ug/mL
Compound 4 ended at the assay's limit (the forecaster's own chance of this, stated with the estimate: 70%); middle value at least 1.6-fold (0.22 log units) away from the limit.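

In this assay compound 4 gives > 50 ug/mL and this is a limit of the assay, not a number. Among the compounds shown here, no step from compound 1, compound 2 or compound 3 to compound 4 can be read from such limits. The compounds shown leave open how far past its limit each of the four lies, and so whether in this assay the group on the carbonyl carbon changes the read-out at all.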